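A few compounds are considered here, and "the series" means these few. Any claim that something is new, unique, unknown or untested is made for them only; others in the source may bear on it.

Measured so far in a functional assay on SGC-7901 cells (Homo sapiens) for cytotoxicity, read by MTT assay, with a stated time of 48 h; a lower number here means a stronger inhibitor, a higher number a weaker inhibitor:
- Compound 1 `Cc1ncc([N+](=O)[O-])n1CCSc1nnc(-c2ccccc2N)o1`: 35100 nM
- Compound 2 `Cc1ncc([N+](=O)[O-])n1CCSc1nnc(-c2ccc(N)cc2)o1`: 31700 nM
- Compound 3 `Cc1ncc([N+](=O)[O-])n1CCSc1nnc(-c2ccccc2O)o1`: 30500 nM

Compound 3 stands level with the other two compounds, as the steps show: a 1.2-fold lower number from compound 1 to compound 3 (0.06 log units; within the scatter), and a 1.0-fold lower number from compound 2 to compound 3 (0.02 log units; within the scatter). Within the data shown here, no compound of the three separates from the others.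

Compound 4 `Cc1ncc([N+](=O)[O-])n1CCSc1nnc(-c2cccnc2)o1` differs from compound 3 in one group: pyridin-3-yl in place of 2-hydroxyphenyl on an aromatic carbon. In words, pyridin-3-yl takes the place of 2-hydroxyphenyl on an aromatic carbon of the shared core.

Among the measured compounds shown here, three measured steps bear on this change, since each alters the group that is exchanged here. Besides the two above, there is a 1.1-fold lower number from compound 1 to compound 2 (0.04 log units; within the scatter). All three are small, but they cover only a narrow range of groups. For the measured compounds named here, none of them replaces a six-membered aromatic ring of carbon only with one holding a hetero atom, so the data offer no direct precedent for this exchange.

No step beyond the scatter is therefore expected in this assay, and no direction can be favoured with confidence. This expectation rests on compound 3 and its 30500 nM. The expected step is a 1.1-fold higher number from compound 3 to compound 4 (0.03 log units; within the scatter).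

For compound 4 the estimated value is 33000 nM, with an expected range from 15000 nM to 70000 nM.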

Compound 4, half-maximal inhibitory concentration: 31600 nM
Compound 4: the middle estimate sits 1.0-fold (0.02 log units) above what was measured; the measured number falls inside the stated range.
By their numbers in this assay, from the lowest: compounds 3, 4, 2 and 1 (each within the scatter of the next).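

In this assay, replacing a six-membered aromatic ring of carbon only with one holding a hetero atom gives no step beyond the scatter: a 1.0-fold higher number from compound 3 to compound 4 (0.02 log units; within the scatter). The same holds when pyridin-3-yl is set against the two aminophenyl groups, with a 1.0-fold lower number from compound 2 to compound 4 (0.00 log units; within the scatter) and a 1.1-fold lower number from compound 1 to compound 4 (0.05 log units; within the scatter), so all four groups on this aromatic carbon of the shared core stand level, and the hydrogen-bond donor of 2-hydroxyphenyl can be given up here without a step beyond the scatter. Nothing at hand accounts for this flat result.

Every group shown at this position is a six-membered aromatic ring, so it remains open whether a carboxylic acid, a simple amine, a longer carbon chain or a saturated ring such as piperidine in the same place would separate from these four compounds in this assay. The rest of the shared core is the same in all four, which leaves open whether any change outside this position would shift the number at all.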